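Ether in place of ester on the shared core: compound 4

A few compounds are considered here, and "the series" means these few. Any claim that something is new, unique, unknown or untested is made for them only; others in the source may bear on it.

Measured in a functional assay on B16 cells (Mus musculus) for antiproliferative activity, read by MTT assay, with a stated time of 24 h; on this read-out higher numbers stand for weaker inhibition and lower numbers for stronger inhibition:
compound 1 `COc1cc(OC)c(-c2coc3cc(OCC=C(C)C)ccc3c2=O)cc1OC`: compound 1 gives 1090 nM
compound 2 `COc1ccc2c(=O)c(-c3cc(OC)c(OC)cc3OC)coc2c1`: compound 2 gives 5200 nM
compound 3 `COc1cccc(C(=O)Oc2ccc3c(=O)c(-c4cc(OC)c(OC)cc4OC)coc3c2)c1`: compound 3 gives only a limit, > 10000 nM

Compound 3 stands at the weak end of what has been measured; its result is the limit of > 10000 nM in this assay, at which 1 of the 3 values shown sits, so no number is known for it, only the limit. The two measured compounds with a number both carry an ether on the same oxygen, and both sit clearly below compound 3: an at least 9.1-fold higher number from compound 1 to compound 3 (0.96 log units; beyond the scatter) and an at least 1.9-fold higher number from compound 2 to compound 3 (0.28 log units; that floor lies within the scatter), while between the two ethers a 4.8-fold higher number from compound 1 to compound 2 (0.68 log units; beyond the scatter).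

Compound 4 `COc1cc(OC)c(-c2coc3cc(OCc4ccc(F)cc4)ccc3c2=O)cc1OC` differs from compound 3 in one place: 4-fluorobenzyl in place of (3-methoxyphenyl)carbonyl on an oxygen on an aromatic ring. The change removes the carbonyl counted in that difference and restores an ether, which is what compound 1 and compound 2 share. The steps into compound 3 therefore bear on the step out of it, in reverse, and a move toward lower numbers is expected, most likely landing in the region of compound 1 rather than compound 2, since compound 1 also carries a larger carbon group on that oxygen. The expected step is an at least 6.6-fold lower number from compound 3 to compound 4 (0.82 log units; beyond the scatter). Compound 4 is estimated at 1500 nM, with a range from 500 nM to 6000 nM.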

Compound 4, half-maximal inhibitory concentration: 1120 nM
Compound 4: the middle estimate sits 1.3-fold (0.13 log units) above what was measured; measured number inside the range.
By their numbers in this assay, from the lowest: compounds 1 and 4 (each within the scatter of the next); then compound 2. At a limit, above all of these: compound 3.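

In this assay, a ring-bearing ether on the oxygen on an aromatic ring reads the same as the open-chain ether, with 4-fluorobenzyl set against 3-methylbut-2-en-1-yl: a 1.0-fold higher number from compound 1 to compound 4 (0.01 log units; within the scatter). Compound 2, with only methyl on that oxygen, now has two larger ethers on its lower side, the new one shown by a 4.6-fold lower number from compound 2 to compound 4 (0.67 log units; beyond the scatter). Compound 3 and compound 4 each carry a six-membered aromatic ring of carbon only on that oxygen, yet an at least 8.9-fold lower number from compound 3 to compound 4 (0.95 log units; beyond the scatter), so the ring alone does not go with the weak result, although the size of this step stays a floor, as compound 3 is held at a limit: the limit of > 10000 nM in this assay, at which 1 of the 4 values shown sits.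

From the compounds shown here alone, the step from compound 3 to compound 4 changes the carbonyl, the methoxy and the fluorine in one move, so the share of each stays open. Also open, going by these compounds, is how this position would read with an amine or a carboxylic acid at the end of a longer chain on that oxygen, and whether the low numbers of the ethers hold with such groups.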